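Nitro for bromo on a pyrrolyl-phenyl oxadiazole core

This account rests on a few compounds, and the source may have more. Where it says the series, first, only, none or still open, it means among the compounds named here.

Measured compounds:
compound 1, `Brc1ccccc1-c1nnc(-c2ccc(-n3cccc3)cc2)o1`, 252000 nM
compound 2, `Brc1ccc(-c2nnc(-c3ccc(-n4cccc4)cc3)o2)cc1`, 264000 nM
compound 3, `O=[N+]([O-])c1ccc(-c2nnc(-c3ccc(-n4cccc4)cc3)o2)cc1`, 258000 nM

Of the compounds shown here, three have been tested in an ADME assay on A549 cells (Homo sapiens) for cytotoxicity, read by MTT assay, with a stated time of 72 h (a higher number here means a weaker inhibitor, a lower number a stronger inhibitor), and all three land close together. Compound 1 and compound 2 share the same atoms joined differently; the difference between the two cores is 2-bromophenyl in place of 4-bromophenyl on an aromatic carbon, and it gave a 1.0-fold higher number from compound 1 to compound 2 (0.02 log units; within the scatter). The change of interest is a swap of one group for another: going from compound 2 to compound 3 the difference is nitro in place of bromo on an aromatic carbon, which gave a 1.0-fold lower number from compound 2 to compound 3 (0.01 log units; within the scatter).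

The unmeasured compound 4, `O=[N+]([O-])c1ccccc1-c1nnc(-c2ccc(-n3cccc3)cc2)o1`, carries the same kind of change relative to compound 1, described as nitro in place of bromo on an aromatic carbon. It is not the same change, though: the group in compound 3 sits para to a large group, whereas in compound 4 it sits ortho to a large group. For the measured compounds named here, with only one prior instance of this swap to go on, and that instance within the scatter, the expected step in this assay is a 1.0-fold higher number from compound 1 to compound 4 (0.01 log units; within the scatter), resting on the small step seen as a 1.0-fold lower number from compound 2 to compound 3 (0.01 log units; within the scatter) and on the near-identical values of compound 1, compound 2 and compound 3. Compound 4 is therefore expected to give about 255000 nM, estimated to fall between 150000 nM and 430000 nM.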

Compound 4, half-maximal inhibitory concentration: 267000 nM
Compound 4: middle estimate off by 1.0-fold (0.02 log units), on the low side; the measured number falls inside the stated range.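

In this assay, putting nitro in place of bromo, ortho to a large group, gave a 1.1-fold higher number from compound 1 to compound 4 (0.03 log units; within the scatter). Set beside the same swap para to a large group, the two results do not differ in any way that can be told apart from ordinary assay noise: the same change on two cores in this assay, a 1.0-fold lower number (0.01 log units; within the scatter) from compound 2 to compound 3 and a 1.1-fold higher number (0.03 log units; within the scatter) from compound 1 to compound 4, 1.1-fold (0.04 log units) apart, within the scatter of two such steps. This shows that, on these two cores, the swap leaves the number within the scatter in both cases, but it does not show that a real effect of the swap carries from one core to another, as neither step is large enough to put that to the test, and two cases say nothing about other cores in the series.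

It remains open whether an amine, a carboxylic acid or a longer chain in the place of the nitro or bromo would give a number clearly apart from the close values of these compounds. Also open, going by these compounds, is whether the swap would still make so little difference with another group in place of the pyrrolyl group, or in any measurement other than this assay.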